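Selenocyanate for bromide on the amide of compound 2

The compounds below may be only part of what the source reports. "The series", "measured", "known", "first", "only" and "open" are said of these compounds alone.

Measured compounds in a functional assay on HCT-116 cells (Homo sapiens) for inhibition, read by MTT assay, with a stated time of 48 h; a higher number here means a weaker inhibitor, a lower number a stronger inhibitor:
compound 1 `COc1ccc(CNc2cc(OC)c(OC)c(OC)c2)cc1[N+](=O)[O-]` gives 18200 nM
compound 2 `COc1ccc(CN(C(=O)C(C)Br)c2cc(OC)c(OC)c(OC)c2)cc1O` gives 140 nM
compound 3 `C/C=C/C(=O)N(Cc1ccc(OC)c(N)c1)c1cc(OC)c(OC)c(OC)c1` gives 300 nM

Compound 2 shows the lowest number of the three in this assay. Compound 3 is the nearest to it, with a higher number that lies beyond the scatter, and compound 1 is the furthest, with a number higher still. Compound 4 `COc1ccc(CN(C(=O)C[Se]C#N)c2cc(OC)c(OC)c(OC)c2)cc1O` is not yet measured. It differs from compound 2 in one place: a group of 4 heavy atoms (2 carbon, 1 nitrogen, 1 selenium; no ring) in place of a group of 3 heavy atoms (2 carbon, 1 bromine; no ring), on a carbonyl carbon. For the measured compounds named here, no step between measured compounds speaks to this exact change, so the account rests on compound 2 alone. Compound 4 is expected to stay close to compound 2, with a step of a 1.8-fold higher number from compound 2 to compound 4 (0.25 log units; within the scatter) that may be modestly toward a higher number in this assay but not far beyond the scatter. Compound 4 is estimated at 250 nM, within 80 nM to 900 nM.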

Compound 4, half-maximal inhibitory concentration: 310 nM
Estimate against measurement, compound 4: 1.2-fold (0.09 log units) below, and the stated range covers the measured number.
By their numbers in this assay, from the lowest: compound 2; then compounds 3 and 4 (each within the scatter of the next); then compound 1.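

Replacing 1-bromoethyl on the carbonyl carbon with the selenocyanate-bearing group gives a 2.2-fold higher number from compound 2 to compound 4 (0.35 log units; beyond the scatter) in this assay as a modest step just beyond the scatter. The bromine is thus not needed at this place for a number in this range, although compound 2 keeps the lower number. No measurement at hand accounts for the step.

The compounds shown leave open how a thiocyanate, a chloride or a longer chain would read on this carbonyl carbon. They also leave open whether selenium itself contributes to the number of compound 4 in this assay.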